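A few compounds are considered here, and "the series" means these few. Any claim that something is new, unique, unknown or untested is made for them only; others in the source may bear on it.

Measured so far:
compound 1, `Cc1ccc(C2CC(c3ccccc3)=NN2c2ccc(S(N)(=O)=O)cc2)cc1`: 7000 nM
compound 2, `Cc1ccc(C2CC(c3ccc(Oc4ccccc4)cc3)=NN2c2ccc(S(N)(=O)=O)cc2)cc1`: 8000 nM

Within the data shown here, in an ADME assay on BHK-21 cells (Mesocricetus auratus) for cytotoxicity, read by MTT assay, with a stated time of 72 h (on this read-out higher numbers stand for lower toxicity in this test and lower numbers for higher toxicity in this test), compound 2 has the highest of the two numbers, and the nearest is compound 1, but the only recorded step, a 1.1-fold higher number from compound 1 to compound 2 (0.06 log units; within the scatter), stays within the scatter. Compound 3, `NS(=O)(=O)c1ccc(N2N=C(c3ccc(Oc4ccccc4)cc3)CC2c2ccccc2F)cc1`, differs from compound 2 by 2-fluorophenyl in place of 4-methylphenyl on a saturated ring carbon. Among the measured compounds shown here, no measured step touches the 4-methylphenyl group on the saturated ring carbon, so nothing recorded speaks to this change; with both numbers near each other in this assay, no step beyond the scatter is expected, and a 1.1-fold lower number from compound 2 to compound 3 (0.03 log units; within the scatter) is the estimate. Compound 3 is therefore expected near 7500 nM, between 3500 nM and 16000 nM.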

Compound 3, half-maximal cytotoxic concentration: 32000 nM
Beside the measured number, compound 3's estimate is 4.3-fold (0.63 log units) below it; measured number above the stated range.
By their numbers in this assay, from the lowest: compounds 1 and 2 (each within the scatter of the next); then compound 3.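

Among these compounds, the saturated ring carbon is the first place where a change moves the number beyond the scatter: in this assay, 2-fluorophenyl in place of 4-methylphenyl gives a 4.0-fold higher number from compound 2 to compound 3 (0.60 log units; beyond the scatter), so toxicity in this test falls with this change. The phenoxy step elsewhere on the core stayed within the scatter. Nothing on hand accounts for this step.

Open, going by these compounds, is whether the step follows the fluorine, its place on the ring or the loss of the methyl. A 4-fluorophenyl, 2-methylphenyl or 2-chlorophenyl group on this carbon would separate these.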